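The compounds below may be only part of what the source reports. "The series", "measured", "known", "first", "only" and "open" are said of these compounds alone.

Measured so far:
- compound 1, `CN(C)c1ccc(C2CC(c3ccc(-n4cncn4)cc3)=NN2C(=O)c2cc(Cl)cc(Cl)c2)cc1`: 5.3%
- compound 2, `C=C(C)C(=O)N1N=C(c2ccc(-n3ccnc3)cc2)CC1c1ccc(N(C)C)cc1`: 1.6%
- compound 3, `COC(=O)CC(=O)N1N=C(c2ccc(-n3ccnc3)cc2)CC1c1ccc(N(C)C)cc1`: 2.1%

All three compounds were tested in a functional assay on HCC1806 cells (Homo sapiens) for inhibition, read by sulforhodamine B assay, tested at 10 uM (a lower number here means less inhibition, a higher number more inhibition at the concentration tested (going by the name of the read-out)), and all three gave low numbers. Compound 3 stands second highest of the three, but its neighbours are close: compound 2 lies a little lower and compound 1 a little higher, and both gaps fall within the scatter, so no ordering among them can be claimed.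

The step now considered leads from compound 3 to compound 4, `CN(C)c1ccc(C2CC(c3ccc(-n4ccnc4)cc3)=NN2C(=O)c2cc(Cl)cc(Cl)c2)cc1`, which has not yet been measured. The change is 3,5-dichlorophenyl in place of (methoxycarbonyl)methyl on a carbonyl carbon.

For the measured compounds named here, only one measured step bears on this position: a number 0.5 percentage points higher from compound 2 to compound 3 (within the scatter). It shows that exchanging the group on that carbonyl carbon left the read-out unchanged within the scatter. Compound 1 carries the same 3,5-dichlorophenyl on its carbonyl carbon, though its core differs elsewhere, and its value is also low. Going by the values given here, no measured step touches the 3,5-dichlorophenyl group itself, so the expectation rests on the flatness of the numbers seen.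

Compound 4 is therefore expected to sit at 4%, between 0% and 12%, a step of a number 1.9 percentage points higher from compound 3 to compound 4 (within the scatter) that is expected to remain within the scatter.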

Compound 4, a percentage reported as inhibition, at one concentration (the size of the read-out at that concentration, not a potency): 44.5%
Compound 4: middle estimate off by 40.5 percentage points, on the low side; measured number above the stated range.
By their numbers in this assay, from the lowest: compounds 2, 3 and 1 (each within the scatter of the next); then compound 4.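

Placing 3,5-dichlorophenyl on the carbonyl carbon in place of (methoxycarbonyl)methyl gives a number 42.4 percentage points higher from compound 3 to compound 4 (beyond the scatter) in this assay, and placing it there in place of 1-methylethenyl gives a number 42.9 percentage points higher from compound 2 to compound 4 (beyond the scatter) with the same clear result, so this position is far from indifferent to what it carries, even though the exchange between the two smaller groups changed nothing beyond the scatter. The dichlorophenyl group does not bring this on its own, since 1H-imidazol-1-yl in place of 1H-1,2,4-triazol-1-yl on an aromatic carbon gives a number 39.2 percentage points higher from compound 1 to compound 4 (beyond the scatter) while the group on the carbonyl carbon stays the same, and among these four compounds only the one holding both groups stands out. Nothing measured here explains why either exchange has so large an effect.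

Going by these compounds, whether the ring or its two chlorine atoms matter more stays open, and a plain phenyl on the carbonyl carbon would separate the two. A reading at one concentration also leaves open how potent compound 4 is.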